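Phenyl for Octyl: Lipophilicity Step from Compound 2 to Compound 3

This account rests on a few compounds, and the source may have more. Where it says the series, first, only, none or still open, it means among the compounds named here.

Compound 1, `CCCCCCCCc1ccc(OC(C)C(=O)Cn2nnc(-c3ccccc3)n2)cc1`: in a physicochemical assay for lipophilicity, read by HPLC, tested at 5 mM (a higher number here means a more lipophilic compound, a lower number a more polar compound), compound 1 gives > 8, which is a limit of the assay.
Compound 2, `CCCCCCCCc1ccc(OC(C)C(=O)Cn2nnc(-c3ccc(C(=O)O)cc3)n2)cc1`: in this assay compound 2 gives 5.9.

Among the measured compounds shown here, of the two values in this assay, that of compound 2 is the only number; the other is a limit, as the limit of > 8 in this assay, at which 1 of the 2 values shown sits, records. For the measured compounds named here, the one measured step, a number at least 2.10 log units lower from compound 1 to compound 2 (beyond the scatter), follows the carboxy in place of hydrogen on an aromatic carbon.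

Compound 3, `CC(Oc1ccc(-c2ccccc2)cc1)C(=O)Cn1nnc(-c2ccc(C(=O)O)cc2)n1`, has not yet been measured. It differs from compound 2 by phenyl in place of octyl on an aromatic carbon. Going by the values given here, no measured step concerns this change; the step from compound 1 to compound 2 touches a different group, so it offers no direct guide. On the structural change alone, the partition coefficient of compound 3 is expected to fall beyond the scatter, by a number 1.90 log units lower from compound 2 to compound 3 (beyond the scatter). Compound 3 is therefore estimated at 4, within 3.2 to 4.8.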

Compound 3, partition coefficient: 2.6
Estimate against measurement, compound 3: 1.40 log units above, and the stated range ends above it.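

Phenyl in place of octyl, on an aromatic carbon para to a large group, gives a number 3.30 log units lower from compound 2 to compound 3 (beyond the scatter) in this assay, so the group held at this position strongly shifts the partition coefficient. Among the compounds shown here, this is the first step with a number at both ends, and it concerns a different place from a number at least 2.10 log units lower from compound 1 to compound 2 (beyond the scatter), so the sizes of the two steps cannot be set against each other. Compound 1 stands at a limit of the assay and not at a number: the limit of > 8 in this assay, at which 1 of the 3 values shown sits.

The compounds shown leave open where a shorter alkyl chain or a cyclohexyl ring at this position would fall relative to compound 2 and compound 3. They also leave open whether phenyl in place of octyl would give a step of similar size without the carboxylic acid on the far aromatic ring.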